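This account rests on a few compounds, and the source may have more. Where it says the series, first, only, none or still open, it means among the compounds named here.

Measured compounds, cytotoxicity in a functional assay on NCI-H460 cells (Homo sapiens) for cytotoxicity, read by MTT assay, with a stated time of 72 h; a higher number here means a weaker inhibitor, a lower number a stronger inhibitor:
compound 1 `CN(C)CCn1cnnc1-c1cc(Oc2ccc(NC(=O)N/N=C/c3c(O)ccc4ccccc34)cc2F)ccn1` gives 890 nM
compound 2 `CN(C)CCn1cnnc1-c1cc(Oc2ccc(NC(=O)N/N=C/c3ccccc3O[N+](=O)[O-])cc2F)ccn1` gives 1270 nM
compound 3 `CN(C)CCn1cnnc1-c1cc(Oc2ccc(NC(=O)N/N=C/c3ccc(F)cc3)cc2F)ccn1` gives 1980 nM

Compound 3 carries the highest number of the three; the steps leading to it are a 2.2-fold higher number from compound 1 to compound 3 (0.35 log units; beyond the scatter) and a 1.6-fold higher number from compound 2 to compound 3 (0.19 log units; within the scatter), so it is separated from only one of the other two beyond the scatter. Compound 4 `COc1cc(/C=N/NC(=O)Nc2ccc(Oc3ccnc(-c4nncn4CCN(C)C)c3)c(F)c2)cc(OC)c1OC` differs from compound 3 at the position where the series already varies: 3,4,5-trimethoxyphenyl in place of 4-fluorophenyl on a carbon with a double bond to nitrogen. The measured steps that bear on this are the three exchanges of the aryl group on that carbon, a 1.4-fold higher number from compound 1 to compound 2 (0.15 log units; within the scatter), a 2.2-fold higher number from compound 1 to compound 3 (0.35 log units; beyond the scatter) and a 1.6-fold higher number from compound 2 to compound 3 (0.19 log units; within the scatter); none of them exceeds a modest size. Going by the values given here, the 3,4,5-trimethoxyphenyl group has no precedent among the measured compounds, so no direction can be fixed from the data, and the earlier exchanges argue for a small response. The step expected for compound 4 is a 1.3-fold lower number from compound 3 to compound 4 (0.12 log units; within the scatter), none beyond the scatter. The estimated value for compound 4 in this assay is 1500 nM, with a range of 500 nM to 4500 nM.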

Compound 4, half-maximal inhibitory concentration: 2770 nM
The estimate for compound 4 lay 1.8-fold (0.27 log units) below the measured number; the measured number falls inside the stated range.
By their numbers in this assay, from the lowest: compounds 1, 2, 3 and 4 (each within the scatter of the next, the first and the last beyond it).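

In this assay, 3,4,5-trimethoxyphenyl on the carbon with a double bond to nitrogen cannot be told apart from 4-fluorophenyl, with a 1.4-fold higher number from compound 3 to compound 4 (0.15 log units; within the scatter). It does separate from the other two aryl groups, with a 2.2-fold higher number from compound 2 to compound 4 (0.34 log units; beyond the scatter) and a 3.1-fold higher number from compound 1 to compound 4 (0.49 log units; beyond the scatter), the latter being the widest step seen at this position, so the four aryl groups now span a range that is still only modest. No supporting data bear on why these steps arise.

On these data alone, all four compounds carry an aromatic ring on this carbon, so the response to an aliphatic amine or a carboxylic acid there remains open. As far as these compounds go, whether the same steps would hold on any core other than the shared one is also open.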